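Flipping One Ring Stereocentre Between Two Diastereomers

The source may hold more compounds than are shown below. What is called first, only, known or untested is meant among the compounds shown, and "the series" means these compounds.

Of the compounds shown here, two have so far been measured in a functional assay for inhibition of Monoamine oxidase (Rattus norvegicus), tested at 10 uM; a lower number here means a weaker effect, a higher number a stronger effect of the compound at the concentration tested. Compound 1 `C(=C/c1ccccn1)\C1=NCCN1` gives 5% in this assay. Compound 2 `c1ccc([C@H]2O[C@H]2C2=NCCN2)cc1` gives 25% in this assay. Going by the values given here, of these two numbers the value of compound 2 is the higher, and the only other value, that of compound 1, lies lower by a margin that is beyond the usual scatter of this kind of measurement. Among the compounds with values here, no pair of measured compounds differs in just one place, so no measured step shows what any single structural change does here.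

Compound 3 `c1ccc([C@H]2O[C@@H]2C2=NCCN2)cc1` is the next compound to be measured in this assay. Compared with compound 2 it differs as follows: the two compounds have the same atoms and bonds and differ only in configuration as drawn: 1 of 2 stereo elements differ; a stereocentre at a saturated ring carbon is drawn S in compound 2 and R in compound 3. Nothing is added and nothing is removed, so only the drawn configuration changes. Within the data shown here, with no measured step of this kind to lean on, the step of no change at the digits printed from compound 2 to compound 3 (within the scatter) is expected to be small, in no preferred direction, and likely within the scatter. Compound 3 is therefore expected to give about 25% in this assay, within a range from 5% to 50%, because compound 2 in this assay gives 25% and the change is one of configuration alone.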

Compound 3, a percentage reported as inhibition, at one concentration (the size of the read-out at that concentration, not a potency): 15%
The estimate for compound 3 lay 10 percentage points above the measured number; the measured number falls inside the stated range.
By their numbers in this assay, from the lowest: compounds 1, 3 and 2 (each within the scatter of the next, the first and the last beyond it).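

Going by these compounds alone, the first step between two compounds that differ in one place can now be read in this assay: a number 10 percentage points lower from compound 2 to compound 3 (within the scatter). It concerns a stereocentre at a saturated ring carbon, drawn S on one side of the step and R on the other, and in this pair reversing that single centre does not separate the two compounds beyond the usual scatter of the measurement. The comparison is a clean test of that one change, because nothing is added or removed and no other part of the structure can account for the numbers: the fact that compounds 2 and 3 differ only in the configuration as drawn

This single pair, read at one concentration, cannot show whether a real but small preference for one configuration lies hidden inside the scatter, nor what reversing the other stereocentre, or both together, would do. It also leaves open whether an amine or a carboxylic acid attached to the shared core would move the read-out beyond the scatter, and whether any configuration preference would then become visible.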